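The source may report more compounds than this note shows. Statements on the series, on what has been measured and on what is new or still open speak of the compounds shown alone.

In an ADME assay on CHO cells (Cricetulus griseus) for cytotoxicity, read by MTT assay (a higher number here means a weaker inhibitor, a lower number a stronger inhibitor), compound 1 (`O=S(=O)(NCC1COC1)c1cccc(-c2ccc3nccc(-c4ccncc4)c3n2)c1`) gives 16000 nM and compound 2 (`CS(=O)(=O)Nc1cccc(-c2ccc3nccc(-c4ccncc4)c3n2)c1`) gives 13000 nM while compound 3 (`O=S(=O)(c1cccc(-c2ccc3nccc(-c4ccncc4)c3n2)c1)N1CC[C@H](O)C1`) gives 9000 nM on the same read-out. Compound 1 therefore stands with the other two, all within the scatter of one another.

Compound 4 (`C[C@@H]1CN(S(=O)(=O)c2cccc(-c3ccc4nccc(-c5ccncc5)c4n3)c2)C[C@H](C)N1`) differs from compound 1 in one place (3,5-dimethylpiperazin-1-yl in place of ((oxetan-3-yl)methyl)amino on a sulfonyl sulfur) on a sulfonyl sulfur whose other neighbour is an aromatic carbon. The closest measured change is at that same sulfur, 3-hydroxypyrrolidin-1-yl in place of ((oxetan-3-yl)methyl)amino (a 1.8-fold lower number from compound 1 to compound 3 (0.25 log units; within the scatter)). The other two steps (a 1.2-fold lower number from compound 1 to compound 2 (0.09 log units; within the scatter)) and (a 1.4-fold lower number from compound 2 to compound 3 (0.16 log units; within the scatter)) are smaller than that one, and all three lie within the scatter. For the measured compounds named here, no measured compound carries 3,5-dimethylpiperazin-1-yl, so the basis is indirect.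

No step beyond the scatter is expected in this assay and no firm direction can be drawn. The expected size is a 1.5-fold lower number from compound 1 to compound 4 (0.16 log units; within the scatter) which stays within the scatter. Compound 4 is estimated at 11000 nM with an expected range from 4500 nM to 25000 nM as the working figure.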

Compound 4, half-maximal inhibitory concentration: 6000 nM
Compound 4: the middle estimate sits 1.8-fold (0.26 log units) above what was measured; the range from low to high includes it.
By their numbers in this assay, from the lowest: compounds 4, 3, 2 and 1 (each within the scatter of the next, the first and the last beyond it).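

In this assay, for the compounds shown here, the sulfonyl sulfur now gives the first steps beyond the scatter: 3,5-dimethylpiperazin-1-yl in place of ((oxetan-3-yl)methyl)amino is a modest change (a 2.7-fold lower number from compound 1 to compound 4 (0.43 log units; beyond the scatter)), and (3,5-dimethylpiperazin-1-yl)sulfonyl in place of methanesulfonamido on an aromatic carbon is also modest (a 2.2-fold lower number from compound 2 to compound 4 (0.34 log units; beyond the scatter)). Against 3-hydroxypyrrolidin-1-yl on the same sulfur, the step stays within the scatter (a 1.5-fold lower number from compound 3 to compound 4 (0.18 log units; within the scatter)), so these two groups are not separated here. Nothing available explains these steps.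

A piperazin-1-yl group without the two methyl groups, or a morpholin-4-yl group, on the same sulfur would show whether the step follows the second ring nitrogen or the methyl groups. As far as these compounds go, the part played by the 2 defined stereocentres of 3,5-dimethylpiperazin-1-yl also stays open.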